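Moving the Chlorine on the Hydroxyphenyl Group

A few compounds are considered here, and "the series" means these few. Any claim that something is new, unique, unknown or untested is made for them only; others in the source may bear on it.

In a functional assay on K562 cells (Homo sapiens) for cytotoxicity, with a stated time of 72 h (on this read-out lower numbers stand for stronger inhibition and higher numbers for weaker inhibition), compound 1 (`CC(C)[C@H](NC(=O)c1cc(Cl)ccc1O)C(=O)Nc1ccc(Cl)cc1`) gives > 20000 nM, which is a limit and not a number. Compound 3 (`CC(C)[C@H](NC(=O)c1cc(Cl)ccc1O)C(=O)Nc1ccccc1`) gives > 10000 nM, which is also a limit. Among the compounds with values here, compound 2 (`CC(C)[C@H](NC(=O)c1cc(Cl)ccc1O)C(=O)Nc1ccc(C(F)(F)F)cc1`) gives 4500 nM, the only full number in this short series. The next compound is compound 4 (`CC(C)[C@H](NC(=O)c1ccc(Cl)cc1O)C(=O)Nc1ccc(Cl)cc1`), which differs from compound 1 by 4-chloro-2-hydroxyphenyl in place of 5-chloro-2-hydroxyphenyl on a carbonyl carbon, with 4-chloro-2-hydroxyphenyl in place of 5-chloro-2-hydroxyphenyl on a carbonyl carbon. Trifluoromethyl in place of chloro gave an at least 4.4-fold lower number from compound 1 to compound 2 (0.64 log units; beyond the scatter). Hydrogen in place of trifluoromethyl gave an at least 2.2-fold higher number from compound 2 to compound 3 (0.34 log units; beyond the scatter), while hydrogen in place of chloro gave a step that the two limits leave unreadable from compound 1 to compound 3. All three steps exchange a group on an aromatic carbon elsewhere in the molecule, so none of them measures the new change directly. No step beyond the scatter is therefore expected in this assay, although a modest move in either direction remains possible. The expected change is a number no higher from compound 1 to compound 4 (the limit leaves the size open). For compound 4 the estimate is 20000 nM, with an expected range of 6000 nM to 60000 nM.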

Compound 4, half-maximal inhibitory concentration: > 10000 nM
Compound 4 gave a limit, no number; the forecaster's own chance of this, stated with the estimate: 60%; the middle value is on the limit's open side.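

Compound 1 and compound 4 both give limits and not numbers in this assay, so no step can be read between them. The compounds shown leave open whether 4-chloro-2-hydroxyphenyl in place of 5-chloro-2-hydroxyphenyl changes the result at all, and in which direction.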